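The source may report more compounds than this note shows. Statements on the series, on what has been measured and on what is new or still open speak of the compounds shown alone.

Of the compounds shown here, three sharing one core have been measured in a functional assay on BT-474 cells (Homo sapiens) for inhibition, read by fluorescence, with a stated time of 72 h; on this read-out lower numbers stand for stronger inhibition of growth and higher numbers for weaker inhibition of growth. Compound 1 `COc1ccc(Nc2nc(N[C@H]3CC[C@H](N)CC3)nc3c2ncn3CCC(C)C)c(OC)c1` gives 7900 nM. Compound 2 `CC(C)CCn1cnc2c(Nc3ccc(Cl)cc3)nc(N[C@H]3CC[C@H](N)CC3)nc21` gives 5100 nM, and compound 3 `CC(C)CCn1cnc2c(Nc3cccc(Cl)c3)nc(N[C@H]3CC[C@H](N)CC3)nc21` gives 3800 nM. Compound 3 therefore sits at the low end of this small set, level with compound 2 within the scatter and clearly apart only from compound 1.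

Compound 4 `CC(C)CCn1cnc2c(Nc3cccc(O)c3)nc(N[C@H]3CC[C@H](N)CC3)nc21` keeps everything in compound 3 except one group: hydroxy in place of chloro on an aromatic carbon. In words, this is hydroxy in place of chloro on an aromatic carbon.

The closest evidence comes from the other changes to this phenyl group. Two of these stay within the scatter: a 1.5-fold lower number from compound 1 to compound 2 (0.19 log units; within the scatter) and a 1.3-fold lower number from compound 2 to compound 3 (0.13 log units; within the scatter). The third, a 2.1-fold lower number from compound 1 to compound 3 (0.32 log units; beyond the scatter), passes just beyond it and is modest. Among the measured compounds shown here, no measured compound carries a hydroxy group, so this evidence is indirect, and no step beyond the scatter is expected in this assay, in either direction.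

The estimated step is a 1.1-fold higher number from compound 3 to compound 4 (0.02 log units; within the scatter). For compound 4, the expected value is 4000 nM, within an estimated range of 1500 nM to 10000 nM.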

Compound 4, concentration for 50% growth inhibition: 14700 nM
Beside the measured number, compound 4's estimate is 3.7-fold (0.57 log units) below it; measured number outside the range, above it.
By their numbers in this assay, from the lowest: compounds 3, 2, 1 and 4 (each within the scatter of the next, the first and the last beyond it).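

In this assay, among the compounds shown here, hydroxy in place of chloro at this position gives the largest step seen so far on this phenyl group (a 3.9-fold higher number from compound 3 to compound 4 (0.59 log units; beyond the scatter)), so this single-atom change matters more than the earlier compounds suggested. Measured against the 4-chlorophenyl group, the 3-hydroxyphenyl group is also beyond the scatter (a 2.9-fold higher number from compound 2 to compound 4 (0.46 log units; beyond the scatter)), while against the 2,4-dimethoxyphenyl group it is not (a 1.9-fold higher number from compound 1 to compound 4 (0.27 log units; within the scatter)), so the hydroxy compound stands apart from both chlorophenyl compounds but not from the dimethoxy one. Nothing shown gives a measured reason for this weaker growth inhibition.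

As far as these compounds go, it remains open whether the shift belongs to hydroxy itself or would follow any replacement of chloro here, such as fluoro, methyl or an amine. From the compounds shown here alone, it is also open whether the same change would have a similar effect on a different core.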